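The source may hold more compounds than are shown below. What is called first, only, known or untested is meant among the compounds shown, and "the series" means these compounds.

Three compounds sharing one core were tested in an ADME assay on MT2 cells (Homo sapiens) for cytotoxicity, read by XTT assay, with a stated time of 4 days; on this read-out higher numbers stand for lower toxicity in this test and lower numbers for higher toxicity in this test. Compound 1, `Cc1cc(/C=C2\SC(=S)N(c3cccc(O)c3)C2=O)c(C)n1-c1cccc(-c2nnn[nH]2)c1`, gives 35600 nM in this assay. Compound 2, `Cc1cc(/C=C2\SC(=S)N(c3cccc(Br)c3)C2=O)c(C)n1-c1cccc(-c2nnn[nH]2)c1`, gives 22600 nM. Compound 3, `Cc1cc(/C=C2\SC(=S)N(c3ccc(O)cc3)C2=O)c(C)n1-c1cccc(-c2nnn[nH]2)c1`, gives 45600 nM. A fourth member of the set, compound 4, `Cc1cc(/C=C2\SC(=S)N(c3ccc(Br)cc3)C2=O)c(C)n1-c1cccc(-c2nnn[nH]2)c1`, has not yet been run in this assay.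

Compound 2 differs from compound 1 by bromo in place of hydroxy on an aromatic carbon. That change produced a 1.6-fold lower number from compound 1 to compound 2 (0.20 log units; within the scatter). Compound 3 differs from compound 1 in its core by 4-hydroxyphenyl in place of 3-hydroxyphenyl on an amide-type nitrogen in a ring, and that pair shows a 1.3-fold higher number from compound 1 to compound 3 (0.11 log units; within the scatter). Between the remaining two the record shows a 2.0-fold higher number from compound 2 to compound 3 (0.30 log units; within the scatter). All three numbers thus sit close together, and none of the three compounds can be called more or less toxic than another on this read-out.

Compound 4 differs from compound 3 by bromo in place of hydroxy on an aromatic carbon. For the measured compounds named here, this is the same kind of change as the one from compound 1 to compound 2, though not the same: in the earlier pair the bromo sits meta to a large group, while in compound 4 it sits para to a large group. Compound 4 is expected to show a 1.5-fold lower number from compound 3 to compound 4 (0.18 log units; within the scatter), a small step of much the same size. That expectation rests on the step of a 1.6-fold lower number from compound 1 to compound 2 (0.20 log units; within the scatter), which stayed within the scatter. On that basis compound 4 is estimated at 30000 nM in this assay. The range expected for compound 4 runs from 15000 nM to 60000 nM.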

Compound 4, half-maximal cytotoxic concentration: 46800 nM
For compound 4 the middle estimate is 1.6-fold (0.19 log units) below the measured one, within the range that was stated.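

In this assay, putting bromo in place of hydroxy on the 4-hydroxyphenyl group gives a 1.0-fold higher number from compound 3 to compound 4 (0.01 log units; within the scatter), and the two readings of this change can be set side by side: the same change on two cores in this assay, a 1.6-fold lower number (0.20 log units; within the scatter) from compound 1 to compound 2 and a 1.0-fold higher number (0.01 log units; within the scatter) from compound 3 to compound 4, 1.6-fold (0.21 log units) apart, within the scatter of two such steps. This shows that the change behaves alike within the scatter on the 3-hydroxyphenyl and 4-hydroxyphenyl versions of the shared core, but with both steps this small it does not show a real effect of the change, and two pairs cannot show that it would carry over to any other core. Of the remaining steps, one shows a 1.3-fold higher number from compound 1 to compound 4 (0.12 log units; within the scatter), while the other, with bromo moved from 3-bromophenyl to 4-bromophenyl, shows a 2.1-fold higher number from compound 2 to compound 4 (0.32 log units; beyond the scatter); this is a modest step that rests on a single pair, and it indicates lower toxicity in this test for compound 4 than for compound 2 without explaining why.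

The compounds shown carry only hydroxy or bromo on this phenyl ring, so it stays open whether an amine, a carboxylic acid or a longer chain such as propyl would leave the number just as unmoved. On these data alone, it also stays open whether any group at all on this ring can shift the number by much more than the modest step seen here.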